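A few compounds are considered here, and "the series" means these few. Any claim that something is new, unique, unknown or untested is made for them only; others in the source may bear on it.

In a functional assay on UMUC3 cells (Homo sapiens) for antiproliferative activity, read by MTT assay, with a stated time of 72 h (on this read-out higher numbers stand for weaker inhibition and lower numbers for stronger inhibition), compound 1 (`CC(C)NC(=N)NC(=N)Nc1ccc(C(F)(F)F)cc1`) gives 5200 nM and compound 2 (`CC(C)CNC(=N)NC(=N)Nc1ccc(F)c(F)c1`) gives 7100 nM, two values within the usual scatter of each other. Compound 3 (`CC(C)NC(=N)NC(=N)Nc1ccc(F)cc1`) reaches only a limit of the assay, > 50000 nM. Compound 4 (`CCN(C)C(=N)NC(=N)Nc1ccc(C(F)(F)F)cc1`) has the same atoms as compound 1, joined differently: ethyl(methyl)amino in place of isopropylamino on a carbon with a double bond to nitrogen. For the measured compounds named here, the only measured step from compound 1, an at least 9.6-fold higher number from compound 1 to compound 3 (0.98 log units; beyond the scatter), lies beyond the scatter but concerns a different place, so it gives no direct size for this change. In this assay, only a small shift towards a higher number is therefore expected, probably within the scatter. The expected step is a 1.4-fold higher number from compound 1 to compound 4 (0.16 log units; within the scatter). For compound 4 the estimated value is 7500 nM, with an expected range from 3000 nM to 25000 nM.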

Compound 4, half-maximal inhibitory concentration: 6900 nM
For compound 4 the middle estimate is 1.1-fold (0.04 log units) above the measured one; measured number inside the range.
By their numbers in this assay, from the lowest: compounds 1, 4 and 2 (each within the scatter of the next). At a limit, above all of these: compound 3.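

On the carbon with a double bond to nitrogen, ethyl(methyl)amino in place of isopropylamino gives a 1.3-fold higher number from compound 1 to compound 4 (0.12 log units; within the scatter) in this assay. This is the first step shown at this place, and the one hydrogen-bond donor counted for isopropylamino is gone in compound 4 with no shift beyond the scatter. Nothing shown here speaks to the cause of this result.

As far as these compounds go, whether a longer chain such as butylamino, or a ring amine such as piperidine, would stay within the scatter of compound 1 remains open. So does whether this swap would read the same with fluoro in place of trifluoromethyl.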